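Amide nitrogen substituent change, compound 2 to compound 3

This account rests on a few compounds, and the source may have more. Where it says the series, first, only, none or still open, it means among the compounds named here.

Compound 1 `COc1cc(-c2cc(C(=O)O)c3ccccc3n2)ccc1OCC(=O)Nc1ccc(C)cc1` carries a 4-methylphenyl on the amide-type nitrogen. In an ADME assay on HaCaT cells (Homo sapiens) for inhibition (on this read-out higher numbers stand for weaker inhibition and lower numbers for stronger inhibition), compound 1 gives only a limit, > 300000 nM; the value of compound 1 sits at the limit of > 300000 nM in this assay, at which 1 of the 2 values shown sits. Among the measured compounds shown here, compound 2 `COc1cc(-c2cc(C(=O)O)c3ccccc3n2)ccc1OCC(=O)Nc1cccc(Cl)c1`, with 3-chlorophenyl in the same place, is the only compound with a number: in this assay compound 2 gives 192000 nM. For the measured compounds named here, the one measured step, an at least 1.5-fold lower number from compound 1 to compound 2 (0.19 log units; that floor lies within the scatter), changes the group on the amide-type nitrogen.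

Compound 3 `COc1cc(-c2cc(C(=O)O)c3ccccc3n2)ccc1OCC(=O)NCc1ccccc1` differs from compound 2 by benzyl in place of 3-chlorophenyl on an amide-type nitrogen. Going by the values given here, the step from compound 1 to compound 2 is the only measured change at this position, and it stays within the scatter, so no step beyond the scatter is expected here either: the step from compound 2 to compound 3 is estimated at a 1.0-fold higher number from compound 2 to compound 3 (0.02 log units; within the scatter). Compound 3 is therefore expected to give about 200000 nM in this assay, within 80000 nM to 300000 nM.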

Compound 3, half-maximal inhibitory concentration: > 300000 nM
Compound 3: only a limit was reported (the forecaster's own chance of this, stated with the estimate: 35%); at least 1.5-fold (0.17 log units) between middle value and limit.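

In this assay compound 3 gives > 300000 nM as a limit only. Benzyl in place of 3-chlorophenyl on the amide-type nitrogen gives an at least 1.5-fold higher number from compound 2 to compound 3 (0.19 log units; that floor lies within the scatter) and, with the earlier step, leaves compound 2 as the only compound with a number, with neither floor clear of the scatter. The step between compound 1 and compound 3 cannot be read, and most of the values at this position are now limits: the limit of > 300000 nM in this assay, at which 2 of the 3 values shown sit.

Benzyl and 3-chlorophenyl differ in both the chlorine and the carbon link to the nitrogen, so the compounds shown do not separate these two changes. On these data alone, whether unsubstituted phenyl, 2-phenylethyl or a chain carrying an amine on this nitrogen would give a number, and how it would compare with compound 2, remains open.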